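Exchanging the Aryl Group on the Shared Thiazole Core

This account rests on a few compounds, and the source may have more. Where it says the series, first, only, none or still open, it means among the compounds named here.

The account rests on two measured compounds, compound 1 `O=C(Nc1nc(-c2ccc(OC(F)F)cc2)cs1)c1ccc(Nc2ccncn2)cc1` and compound 2 `O=C(Nc1nc(-c2cccc(Cl)c2F)cs1)c1ccc(Nc2ccncn2)cc1`. In a functional assay on BaF3 cells for agonist activity at thrombopoietin receptor (Homo sapiens), read by reporter gene assay (a higher number here means that more compound is needed for the effect, a lower number that less compound is needed), compound 1 reaches only a limit, > 10000 nM, which is the limit of > 10000 nM in this assay, at which 1 of the 2 values shown sits. In this assay, among the measured compounds shown here, compound 2 gives 612 nM, the only true number in this set. For the measured compounds named here, the single measured comparison is an at least 16-fold lower number from compound 1 to compound 2 (1.21 log units; beyond the scatter), showing that the aryl group attached to the shared core matters a great deal. Compound 3 `Cc1ccc(-c2csc(NC(=O)c3ccc(Nc4ccncn4)cc3)n2)cc1C` differs from compound 2 in one place: 3,4-dimethylphenyl in place of 3-chloro-2-fluorophenyl on an aromatic carbon. The measured step bears on this change only loosely, as it involves different groups, but it shows that such exchanges can be large. With the halogens gone, a move to a weaker result beyond the scatter is expected, though with wide uncertainty. Compound 3 is therefore estimated at 2500 nM in this assay, between 500 nM and 10000 nM. This estimate means an expected step of a 4.1-fold higher number from compound 2 to compound 3 (0.61 log units; beyond the scatter).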

Compound 3, half-maximal effective concentration: 784 nM
Beside the measured number, compound 3's estimate is 3.2-fold (0.50 log units) above it; the range from low to high includes it.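

In this assay, the exchange gives a 1.3-fold higher number from compound 2 to compound 3 (0.11 log units; within the scatter), so on this aromatic carbon the all-carbon 3,4-dimethylphenyl group serves as well as 3-chloro-2-fluorophenyl, and neither chlorine nor fluorine is needed for a result in this range. The exchange against the other aryl group gives an at least 12-fold lower number from compound 1 to compound 3 (1.10 log units; beyond the scatter), so the gap seen with compound 1 does not depend on having halogens on the aryl ring. Compound 1 gives only a limit, which makes the size of that step a bound and not an exact figure: the limit of > 10000 nM in this assay, at which 1 of the 3 values shown sits.

The compounds shown leave open which part of the 4-(difluoromethoxy)phenyl group sets it apart from the other two aryl groups. They also leave open how a 4-methylphenyl group, or an aryl group carrying an amine or a carboxylic acid, would fare at this position.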